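The source may report more compounds than this note shows. Statements on the series, on what has been measured and on what is new or still open speak of the compounds shown alone.

Measured compounds, all in a functional assay on HepG2 cells (Homo sapiens) for cytotoxicity, read by MTT assay, with a stated time of 72 h; on this read-out higher numbers stand for weaker inhibition and lower numbers for stronger inhibition:
- compound 1 `COc1c(OCCCCN2CCN(C)CC2)cc(O)c2c(=O)cc(-c3ccc(F)cc3Br)oc12` gives 2130 nM
- compound 2 `CN(C)CCCOc1c(OCc2ccccc2)cc(O)c2c(=O)cc(-c3ccccc3)oc12` gives 4950 nM
- compound 3 `CCN(CC)CCCOc1c(OCc2ccccc2)cc(O)c2c(=O)cc(-c3ccccc3)oc12` gives 3010 nM

Compound 3 sits in the middle of the three numbers, and its gaps to compound 1 and to compound 2 are both within the scatter, so no ordering among the three can be claimed.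

The next compound is compound 4 `CN1CCN(CCCOc2c(OCc3ccccc3)cc(O)c3c(=O)cc(-c4ccccc4)oc23)CC1`. The change from compound 3 is 4-methylpiperazin-1-yl in place of diethylamino on a saturated chain carbon, three bonds along the chain from an oxygen on an aromatic ring. Among the compounds with values here, the one measured step that touches the same position is a 1.6-fold lower number from compound 2 to compound 3 (0.22 log units; within the scatter), which swapped one acyclic amine for another and stayed within the scatter. Compound 1 carries the same 4-methylpiperazin-1-yl group, but on a longer chain and with a differently substituted aryl group and a methoxy group on the core, so its value of 2130 nM bears on compound 4 only loosely; it does show that this amine is compatible with a number in the same region as compound 3.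

Within the data shown here, with the only relevant step within the scatter, no step beyond the scatter is expected in this assay for compound 4, in either direction; the expected step is a 1.1-fold lower number from compound 3 to compound 4 (0.03 log units; within the scatter). The estimate for compound 4 is 2800 nM, with a range from 1200 nM to 6500 nM.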

Compound 4, half-maximal inhibitory concentration: 3110 nM
Compound 4: the middle estimate sits 1.1-fold (0.05 log units) below what was measured; measured number inside the range.
By their numbers in this assay, from the lowest: compounds 1, 3, 4 and 2 (each within the scatter of the next, the first and the last beyond it).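

In this assay, 4-methylpiperazin-1-yl, with its six-membered non-aromatic ring, can now be set directly against both acyclic amines at this position, on a saturated chain carbon, three bonds along the chain from an oxygen on an aromatic ring: a 1.0-fold higher number from compound 3 to compound 4 (0.01 log units; within the scatter), and a 1.6-fold lower number from compound 2 to compound 4 (0.20 log units; within the scatter). Both steps stay within the scatter, so neither the move from an acyclic amine to this ring nor the added heavy atoms separate compound 4 from compound 2 or compound 3 on this read-out, and the three amines cannot be ranked. The compounds shown come with no measurement that could account for this flat result.

Still open, on these data alone, is whether a morpholin-4-yl group, a piperidin-1-yl group, a primary amine or a carboxylic acid at the end of the same 3-carbon propyl chain would stay within the scatter of these three compounds. Compound 1 carries 4-methylpiperazin-1-yl on a longer chain but also differs elsewhere, so the effect of a longer chain alone cannot be read from the compounds shown.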